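A Pyridine Replaces the Pyrimidine of the Weakest Compound

This account rests on a few compounds, and the source may have more. Where it says the series, first, only, none or still open, it means among the compounds named here.

In a functional assay on U2OS cells for antagonist activity at C-X-C chemokine receptor type 3 (Homo sapiens), read by beta-arrestin recruitment (a lower number here means a stronger inhibitor, a higher number a weaker inhibitor), compound 1 `CCCc1ncc(-c2nc(C(F)(F)F)sc2N2CCN(C(=O)Cn3cnc4cccnc43)[C@H](C)C2)cn1` gives 33 nM, compound 2 `CCOc1ncc(-c2nc(C(F)(F)F)sc2N2CCN(C(=O)Cn3nc(C)cc3C)[C@H](C)C2)cn1` gives 87 nM, and compound 3 `CCc1ncc(-c2nc(C(F)(F)F)sc2N2CCN(C(=O)Cn3nc(C)nc3C)[C@H](C)C2)cn1` gives 1430 nM, the highest number of the three and beyond the scatter from both others. Compound 4 `Cc1nc(C)n(CC(=O)N2CCN(c3sc(C(F)(F)F)nc3-c3ccc(C(F)(F)F)nc3)C[C@H]2C)n1` differs from compound 3 only in the ring on the shared core: 6-(trifluoromethyl)pyridin-3-yl in place of 2-ethylpyrimidin-5-yl on an aromatic carbon. For the measured compounds named here, no measured pair mirrors this exchange, so no step can be borrowed. The author therefore expects a modest change in this assay, most likely toward a somewhat lower number but with the direction not settled, so that the step of a 2.4-fold lower number from compound 3 to compound 4 (0.38 log units; beyond the scatter) is an estimate and nothing more. Compound 4 is estimated at 600 nM, within a range of 120 nM to 3000 nM.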

Compound 4, half-maximal inhibitory concentration: 608 nM
Estimate against measurement, compound 4: 1.0-fold (0.01 log units) below; the measured number falls inside the stated range.
By their numbers in this assay, from the lowest: compound 1; then compound 2; then compound 4; then compound 3.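

In this assay, for the compounds shown here, the change of 6-(trifluoromethyl)pyridin-3-yl for 2-ethylpyrimidin-5-yl gives a 2.4-fold lower number from compound 3 to compound 4 (0.37 log units; beyond the scatter), the first step in this set that can be read at a single place. This place on the shared core therefore accepts a ring with one fewer hetero atom and a trifluoromethyl group, and the change is modest. Nothing measured here accounts for the step.

The ring and its substituent change together, and the compounds shown do not separate the two. They also leave open how a methoxy group or an amine on the pyridine would read.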